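A few compounds are considered here, and "the series" means these few. Any claim that something is new, unique, unknown or untested is made for them only; others in the source may bear on it.

Measured compounds:
Compound 1 `COC(=O)c1cc(-c2cccc(NC(=O)c3ccc(/C=C/C(=O)c4cccs4)cc3)c2)on1`, in an ADME assay on Vero cells (Chlorocebus sabaeus) for cytotoxicity, read by MTT assay, with a stated time of 72 h (a higher number here means that more compound is tolerated, a lower number that less compound is tolerated), compound 1 gives "not determined" (no result reported).
Compound 2 `COC(=O)c1cc(-c2cccc(NC(=O)c3ccc(/C=C/C(=O)c4cccc(Cl)c4)cc3)c2)on1`, for which compound 2 gives > 2.5 ug/mL, a limit of the assay rather than a number.

Compound 2 therefore stands at the limit of > 2.5 ug/mL in this assay, at which 1 of the 2 values shown sits, with no single value alongside it. Compound 3 `COC(=O)c1cc(-c2cccc(NC(=O)c3ccc(/C=C/C(=O)c4ccc(OC)cc4OC)cc3)c2)on1` differs from compound 2 by 2,4-dimethoxyphenyl in place of 3-chlorophenyl on a carbonyl carbon. Within the data shown here, no step between measured compounds is available here, so no change beyond the usual scatter is expected from compound 2 to compound 3, and compound 3 will most likely also return only a limit. Compound 3 is estimated at 5 ug/mL, from 2 ug/mL to 15 ug/mL, which means an expected step that the limit leaves unreadable from compound 2 to compound 3.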

Compound 3, half-maximal cytotoxic concentration: > 50 ug/mL
Compound 3: only a limit was reported; the forecaster's own chance of this, stated with the estimate: 70%; middle value at least 10-fold (1.00 log units) from the limit.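

Among these compounds, compound 2 and compound 3 each return only a limit of the assay, not a number, so no step between them can be read. On these data alone, what stays open is the concentration each compound actually tolerates.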